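Swapping a Methoxy for a Fluoro on the Core

This account rests on a few compounds, and the source may have more. Where it says the series, first, only, none or still open, it means among the compounds named here.

Compound 1 `COc1ccc(C2=NN(c3ccccc3)C(c3ccc(OC)cc3)C2O)cc1`: 10.2 nM
Compound 2 `COc1ccc(C2=CC(c3ccc(Br)cc3)NC(=S)N2)cc1`: 30 nM

In a functional assay on HepG2 cells (Homo sapiens) for antiproliferative activity, read by sulforhodamine B assay, with a stated time of 48 h (a higher number here means a weaker inhibitor, a lower number a stronger inhibitor), compound 1 gives 10.2 nM, the lower of the two numbers and so the stronger inhibitor. Compound 2 gives 30 nM, and that gap lies beyond the usual scatter. These two compounds differ in more than one place, so they say little about any single change.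

Compound 3 `COc1ccc(C2=NN(c3ccccc3)C(c3ccc(F)cc3)C2O)cc1` has yet to be measured. It keeps the core of compound 1 but has fluoro in place of methoxy on an aromatic carbon, para to a large group, a change from 4-methoxyphenyl to 4-fluorophenyl: fluoro in place of methoxy on an aromatic carbon. Among the measured compounds shown here, no measured pair shows this swap, so any forecast is loose. Compound 1 already sits low at 10.2 nM, so the expected move is a small rise or nothing beyond the scatter: a 1.8-fold higher number from compound 1 to compound 3 (0.25 log units; within the scatter). For compound 3 the estimated value is 18 nM, with an expected range of 6 nM to 60 nM.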

Compound 3, half-maximal inhibitory concentration: 13 nM
Compound 3: the middle estimate sits 1.4-fold (0.14 log units) above what was measured, and the stated range covers the measured number.
By their numbers in this assay, from the lowest: compounds 1 and 3 (each within the scatter of the next); then compound 2.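

Among the compounds shown here, the change from 4-methoxyphenyl to 4-fluorophenyl gives a 1.3-fold higher number from compound 1 to compound 3 (0.11 log units; within the scatter) in this assay, and this is the first comparison here that isolates a single place. On this aromatic carbon, para to a large group, a methoxy with 2 heavy atoms and 1 hydrogen-bond acceptor gives way to a fluoro with 1 heavy atom and no hydrogen-bond acceptor, yet the two numbers cannot be told apart. No supporting measurement speaks to why the swap leaves the read-out within the scatter.

From the compounds shown here alone, what an amine, a carboxylic acid or a longer chain such as butoxy would do at this same place remains open. Also open, going by these compounds, is whether the other 4-methoxyphenyl group, kept in both compound 1 and compound 3, would accept the same swap.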